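Swapping Ethynyl for Iodo on Two Nucleoside Cores

A few compounds are considered here, and "the series" means these few. Any claim that something is new, unique, unknown or untested is made for them only; others in the source may bear on it.

Compound 1, `C#Cc1cn([C@@H]2O[C@H](CO)[C@@H](O)[C@H]2O)c2nc(C)nc(N)c12`, and compound 2, `Cc1nc(N)c2c(I)cn([C@@H]3O[C@H](CO)[C@@H](O)[C@H]3O)c2n1`, share one core and differ in a single group. In a functional assay on A549 cells (Homo sapiens), read by MTT assay, with a stated time of 72 h (on this read-out lower numbers stand for stronger inhibition and higher numbers for weaker inhibition), compound 1 gives > 20000 nM, which is a limit of the assay and not a number, as the limit of > 20000 nM in this assay, at which 1 of the 3 values shown sits, shows. In this assay compound 2 gives 12100 nM. The change between the two is iodo in place of ethynyl on an aromatic carbon, and it brought an at least 1.6-fold lower number from compound 1 to compound 2 (0.21 log units; that floor lies within the scatter).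

Compound 3, `C#Cc1cn([C@@H]2O[C@H](CO)[C@@H](O)[C@H]2O)c2ncnc(OC)c12`, carries a different core; the difference between the two cores is not broken down here. In this assay compound 3 gives 8160 nM, a value lying within the usual scatter of that of compound 2, so no order between those two is claimed. Compound 4, `COc1ncnc2c1c(I)cn2[C@@H]1O[C@H](CO)[C@@H](O)[C@H]1O`, has not yet been measured. It differs from compound 3 by iodo in place of ethynyl on an aromatic carbon, the same change, at the same place, as that seen between compound 1 and compound 2.

The expected step, which rests on an at least 1.6-fold lower number from compound 1 to compound 2 (0.21 log units; that floor lies within the scatter), is a 1.3-fold lower number from compound 3 to compound 4 (0.10 log units; within the scatter). That earlier step set only a floor, so the expectation is a modest lowering, not a large one. In this assay compound 4 is therefore expected to give about 6500 nM. The expected range for compound 4 runs from 2500 nM to 16000 nM.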

Compound 4, half-maximal inhibitory concentration: > 20000 nM
Compound 4 ended at the assay's limit; the forecaster's own chance of this, stated with the estimate: 10%; at least 3.0-fold (0.48 log units) between middle value and limit.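

In this assay, putting iodo in place of ethynyl on the second core brought an at least 2.4-fold higher number from compound 3 to compound 4 (0.38 log units; beyond the scatter). The step seen on one core therefore did not carry over to the other, so in this series a change measured on one core cannot simply be assumed to repeat on a different one, and the two steps differ by more than chance scatter would explain: the same change on two cores in this assay, an at least 1.6-fold lower number (0.21 log units; that floor lies within the scatter) from compound 1 to compound 2 and an at least 2.4-fold higher number (0.38 log units; beyond the scatter) from compound 3 to compound 4, at least 4.0-fold (0.60 log units) apart, beyond the scatter of two such steps. Compound 1 and compound 4 each sit at a limit of the assay and not at a number, so the true size of both steps remains unknown, and nothing here shows why the two cores part ways: the limit of > 20000 nM in this assay, at which 2 of the 4 values shown sit.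

Among the compounds shown here, with only two pairs, and with the cores differing in more than one group, it stays open which feature of the core decides the outcome of the swap. Going by these compounds, it also stays open how a group other than ethynyl or iodo, such as a nitrile or a longer chain, would fare on this aromatic carbon of either core.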